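The source may report more compounds than this note shows. Statements on the series, on what has been measured and on what is new or still open speak of the compounds shown alone.

Working notes on the series. The unsubstituted amide `NC(=O)c1ccc(C#Cc2ccccc2)nc1` is compound 1; in a functional assay on BHK cells for positive allosteric modulation of metabotropic glutamate receptor 5 (Homo sapiens), read by FLIPR and calcium flux (a higher number here means that more compound is needed for the effect, a lower number that less compound is needed), compound 1 gives 6600 nM. Compound 2, `CC1CCC(NC(=O)c2ccc(C#Cc3ccccc3)nc2)CC1`, carries a 4-methylcyclohexyl group on the amide-type nitrogen and in this assay compound 2 gives 1200 nM. For the measured compounds named here, the single measured step, a 5.5-fold lower number from compound 1 to compound 2 (0.74 log units; beyond the scatter), is beyond the scatter, so compound 2 stands lowest of the two numbers in this assay, with compound 1 as its only neighbour.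

Compound 3, `O=C(c1ccc(C#Cc2ccccc2)nc1)N1CCCCC1`, differs from compound 2 in one place: piperidin-1-yl in place of (4-methylcyclohexyl)amino on a carbonyl carbon. Going by the values given here, no measured step bears directly on this change; the only measured step shows that a six-membered ring attached through the amide nitrogen is tolerated in this assay. Without a donor on that nitrogen, a modest move upward is expected, and the step of a 2.1-fold higher number from compound 2 to compound 3 (0.32 log units; beyond the scatter) is the expected size. For compound 3 the estimate in this assay is 2500 nM, with a range from 700 nM to 9000 nM.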

Compound 3, half-maximal effective concentration: 280 nM
Compound 3: middle estimate off by 8.9-fold (0.95 log units), on the high side; the whole stated range lies above it.
By their numbers in this assay, from the lowest: compound 3; then compound 2; then compound 1.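

In this assay the hydrogen-bond donor of the amide is not needed at this carbonyl carbon: piperidin-1-yl, which has none, gives a 4.3-fold lower number from compound 2 to compound 3 (0.63 log units; beyond the scatter) and brings fewer heavy atoms than (4-methylcyclohexyl)amino. Replacing amino with the same ring gives a 24-fold lower number from compound 1 to compound 3 (1.37 log units; beyond the scatter), so the order does not follow heavy-atom count, since the group of intermediate size gives the lowest number. No evidence on hand accounts for this result.

The compounds shown do not separate the loss of the donor from the change in ring and its point of attachment. Open-chain diethylamino, morpholin-4-yl and 4-methylpiperidin-1-yl on the same carbonyl carbon would each test a different part of that question.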